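This account rests on a few compounds, and the source may have more. Where it says the series, first, only, none or still open, it means among the compounds named here.

Measured so far in a functional assay on cells (Peritoneal macrophage, Mus musculus) for cytotoxicity, with a stated time of 24 h; on this read-out higher numbers stand for lower toxicity in this test and lower numbers for higher toxicity in this test:
Compound 1 `CCCCC(=O)Nc1ccc(S(=O)(=O)N(CC(N)=O)c2ccc(N(CC(N)=O)S(=O)(=O)c3ccc(OC)cc3)c3ccccc23)cc1` gives > 100000 nM, a limit of the assay.
Compound 2 `COc1ccc(S(=O)(=O)N(CC(N)=O)c2ccc(N(CC(N)=O)S(=O)(=O)c3ccc(NC(=O)CN4CCC(C)CC4)cc3)c3ccccc23)cc1` gives > 50000 nM, a limit of the assay.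
Compound 3 `CCN1CCN(CC(=O)Nc2ccc(S(=O)(=O)N(CC(N)=O)c3ccc(N(CC(N)=O)S(=O)(=O)c4ccc(OC)cc4)c4ccccc34)cc2)CC1` gives > 100000 nM, a limit of the assay.

Compound 2 stands only at a limit; every value shown is a limit, two sitting at the limit of > 100000 nM in this assay, at which 2 of the 3 values shown sit, and one at the limit of > 50000 nM in this assay, at which 1 of the 3 values shown sits. Compound 4 `COc1ccc(S(=O)(=O)N(CC(N)=O)c2ccc(N(CC(N)=O)S(=O)(=O)c3ccc(NC(=O)CCN4CCC(C)CC4)cc3)c3ccccc23)cc1` differs from compound 2 by (4-methylpiperidin-1-yl)methyl in place of 4-methylpiperidin-1-yl on a saturated chain carbon bound to a carbonyl carbon. Going by the values given here, the steps a step that the two limits leave unreadable from compound 1 to compound 2, a step that the two limits leave unreadable from compound 1 to compound 3 and a step that the two limits leave unreadable from compound 2 to compound 3, all at the same place, are each unreadable from the two limits, so no size of step in this assay can be read for the change to compound 4, in either direction or none. Compound 4 is expected to remain at a limit, with an estimate of 80000 nM (range 30000 nM to 200000 nM). The expected step is a step that the limit leaves unreadable from compound 2 to compound 4.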

Compound 4, half-maximal cytotoxic concentration: > 100000 nM
Compound 4 ended at the assay's limit; the forecaster's own chance of this, stated with the estimate: 85%; at least 1.2-fold (0.09 log units) between middle value and limit.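

Going by these compounds alone, compound 4 stands at a limit in this assay, as do compound 1, compound 2 and compound 3, so no step to compound 4 can be read. The concentration at which any of these compounds turns cytotoxic, and whether their side chains differ, stays open.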